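The source may hold more compounds than are shown below. What is called first, only, known or untested is meant among the compounds shown, and "the series" means these compounds.

Compound 1 `Oc1cccc2[nH]c(-c3ccc(-c4ccc(-c5ccc(F)cc5)cc4)cc3)nc12` and compound 2 `Oc1cccc2[nH]c(-c3ccc(-c4ccc(-c5ccc(C(F)(F)F)cc5)cc4)cc3)nc12` share one core, while compound 3 `Cc1ccc2[nH]c(-c3ccc(-c4ccc(-c5ccc(F)cc5)cc4)cc3)nc2c1` and compound 4 `Cc1ccc2[nH]c(-c3ccc(-c4ccc(-c5ccc(C(F)(F)F)cc5)cc4)cc3)nc2c1` share another; the difference between the two cores is not broken down here. In a functional assay on KB cells (Homo sapiens) for inhibition, read by sulforhodamine B assay (a lower number here means a stronger inhibitor of growth, a higher number a weaker inhibitor of growth), compound 1 gives 6920 nM, and compound 2 gives 4320 nM. The change between them is trifluoromethyl in place of fluoro on an aromatic carbon, and it made a step of a 1.6-fold lower number from compound 1 to compound 2 (0.20 log units; within the scatter). In this assay compound 3 gives 24900 nM, the highest of the three numbers. Compound 4 carries the same change, made on the core of compound 3: trifluoromethyl in place of fluoro on an aromatic carbon. The step from compound 3 to compound 4 is expected to be about a 1.6-fold lower number from compound 3 to compound 4 (0.21 log units; within the scatter), because a 1.6-fold lower number from compound 1 to compound 2 (0.20 log units; within the scatter) was small and within the scatter. Compound 4 is therefore estimated to give about 15500 nM, expected between 7000 nM and 35000 nM.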

Compound 4, concentration for 50% growth inhibition: 41200 nM
Estimate against measurement, compound 4: 2.7-fold (0.42 log units) below, outside the stated range (above it).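

In this assay, trifluoromethyl in place of fluoro on the core of compound 3 gives a 1.7-fold higher number from compound 3 to compound 4 (0.22 log units; within the scatter), and the two steps point opposite ways yet do not truly differ: the same change on two cores in this assay, a 1.6-fold lower number (0.20 log units; within the scatter) from compound 1 to compound 2 and a 1.7-fold higher number (0.22 log units; within the scatter) from compound 3 to compound 4, 2.7-fold (0.42 log units) apart, within the scatter of two such steps So on these two cores the change stays small, but two pairs cannot show that it would stay small on any other core. The larger step comes with the core, as 5-methyl-1H-benzimidazol-2-yl in place of 4-hydroxy-1H-benzimidazol-2-yl gives a 9.5-fold higher number from compound 2 to compound 4 (0.98 log units; beyond the scatter).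

The compounds shown leave open whether the hydroxy group or the methyl group accounts for that step, since the two cores differ in more than one place. They also leave open what an amine or a carboxylic acid in place of the fluoro would do.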